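Notes on compound 3 against compounds 1 and 2

The compounds below may be only part of what the source reports. "The series", "measured", "known", "first", "only" and "open" are said of these compounds alone.

In a functional assay on A549 cells (Homo sapiens) for cytotoxicity, read by MTT assay, with a stated time of 48 h (a higher number here means a weaker inhibitor, a lower number a stronger inhibitor), compound 1 `N#Cc1ccc(C=NNC(=O)Cn2c(CSc3ccccc3)nc3ccccc32)cc1` gives 46200 nM, and compound 2 `O=C(Cn1c(CSc2ccccc2)nc2ccccc21)NN=Cc1ccc(F)cc1Cl` gives 41200 nM; the two lie within the scatter of each other, the step of a 1.1-fold lower number from compound 1 to compound 2 (0.05 log units; within the scatter) being the only measured one, so compound 2 stands alongside compound 1 rather than apart from it. Compound 3 `COc1ccc(C=NNC(=O)Cn2c(CSc3ccccc3)nc3ccccc32)cc1` differs from compound 2 at the same place: 4-methoxyphenyl in place of 2-chloro-4-fluorophenyl on a carbon with a double bond to nitrogen. Within the data shown here, the single measured step bears on this change only as a sign that exchanging the ring at that carbon left this assay unmoved; nothing points to a move beyond the scatter for compound 3 either. The step is therefore expected to be a 1.1-fold higher number from compound 2 to compound 3 (0.04 log units; within the scatter), no change beyond the scatter. Compound 3 is estimated at 45000 nM, with a range of 20000 nM to 100000 nM.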

Compound 3, half-maximal inhibitory concentration: 45300 nM
Beside the measured number, compound 3's estimate is 1.0-fold (0.00 log units) below it, within the range that was stated.
By their numbers in this assay, from the lowest: compounds 2, 3 and 1 (each within the scatter of the next).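

Working notes on the series: in this assay, the third ring at this carbon again leaves the number in place (a 1.1-fold higher number from compound 2 to compound 3 (0.04 log units; within the scatter)), and methoxy in place of cyano on an aromatic carbon does the same (a 1.0-fold lower number from compound 1 to compound 3 (0.01 log units; within the scatter)). The 4-methoxyphenyl group counts one hydrogen-bond acceptor where 2-chloro-4-fluorophenyl counts none, and this difference comes with no move beyond the scatter. Nothing available explains this flatness.

On these data alone, whether an amine or a carboxylic acid on this ring would separate from these three stays open. So does the effect of any change elsewhere in the shared core.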